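The source may report more compounds than this note shows. Statements on the series, on what has been measured and on what is new or still open speak of the compounds shown alone.

In a functional assay on cells (Homo sapiens) for cytotoxicity, read by MTT assay, with a stated time of 72 h (on this read-out lower numbers stand for stronger inhibition and higher numbers for weaker inhibition), compound 1 (`COc1ccc(C(=O)n2c(C(C)C)nc3ccccc32)cc1`) gives > 10000 nM as a limit of the assay, not a number. Compound 2 (`COc1ccc(C(=O)n2c(C3CCCC3)nc3ccccc32)cc1`) gives > 10000 nM as a limit too, so its standing in the series has no numerical value. The step that the two limits leave unreadable from compound 1 to compound 2 is the only measured one and has no readable size. The evidence so far amounts to this: the limit of > 10000 nM in this assay, at which 2 of the 2 values shown sit, is all the series shows. In compound 3 (`COc1ccc(C(=O)n2c(-c3ccc(OC)cc3)nc3ccccc32)cc1`) 4-methoxyphenyl stands in place of cyclopentyl on an aromatic carbon (4-methoxyphenyl in place of cyclopentyl on an aromatic carbon). Among the compounds with values here, no measured step covers an aromatic group at this place, so no step size carries over. A modest move toward stronger inhibition in this assay is expected, though another limit is slightly more likely than a number. Estimated for compound 3: 6000 nM as the middle, 800 nM as the lower end and 20000 nM as the upper end. The estimate means an at least 1.6-fold lower number from compound 2 to compound 3 (0.22 log units; that floor lies within the scatter) as the expected step.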

Compound 3, half-maximal inhibitory concentration: > 10000 nM
Compound 3: no number, only a limit; the forecaster's own chance of this, stated with the estimate: 55%; at least 1.6-fold (0.22 log units) between middle value and limit.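

Within the data shown here, compound 1, compound 2 and compound 3 all stand at a limit, not a number, in this assay; no step among them can be read. Still open is whether any group at this place gives a readable value: the limit of > 10000 nM in this assay, at which 3 of the 3 values shown sit.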